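Methoxy in place of chloro: working notes on the series

The compounds below may be only part of what the source reports. "The series", "measured", "known", "first", "only" and "open" are said of these compounds alone.

Of the compounds shown here, three have been read in a functional assay on HO8910 cells (Homo sapiens) for inhibition, read by MTT assay, with a stated time of 24 h, tested at 100 ug/mL; a higher number here means more inhibition of growth at the concentration tested, a lower number less inhibition of growth. Compound 1 `O=C(CCCCC1CCSS1)Nc1ccccn1` gives 51.9%. Compound 2 `O=C(CCCCC(S)CCS)Nc1ccccc1Cl` is reported as "not active" (no number reported), with no number. Compound 3 `O=C(CCCCC(S)CCS)Nc1ccc(Cl)cc1` gives 21.3%, the lower of the two numbers available, and its gap to compound 1 lies beyond the scatter.

Next in line is compound 4 `COc1ccc(NC(=O)CCCCC(S)CCS)cc1`, which differs from compound 3 in one place: methoxy in place of chloro on an aromatic carbon. Methoxy stands in place of chloro on an aromatic carbon of a six-membered aromatic ring of carbon only, para to a large group. Among the compounds with values here, the measured compounds offer no single-place step as a precedent for this change. No step beyond the scatter is expected in this assay, in either direction. The expectation therefore starts from compound 3 at 21.3%. The estimated step is a number 2.7 percentage points higher from compound 3 to compound 4 (within the scatter), expected to stay within the scatter. Compound 4 is expected at 24%, with an estimated range of 8% to 45%.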

Compound 4, percent growth inhibition at one concentration: 12.6%
Beside the measured number, compound 4's estimate is 11.4 percentage points above it, within the range that was stated.
By their numbers in this assay, from the lowest: compounds 4 and 3 (each within the scatter of the next); then compound 1.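

In this assay, within the data shown here, methoxy in place of chloro on an aromatic carbon, para to a large group, provides the first single-place step, a number 8.7 percentage points lower from compound 3 to compound 4 (within the scatter), so this exchange does not separate the two compounds at this position. The added hydrogen-bond acceptor counted for methoxy therefore comes with no step beyond the scatter in this read-out. No measurement at hand bears on the reason for this result.

On these data alone, whether an amine or a carboxylic acid at this same position would give a step beyond the scatter remains open. Also open, as far as these compounds go, is whether methoxy in place of chloro would give a similar step at another carbon of the aromatic ring, or on the core of compound 1.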